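Trifluoromethoxy in Place of Methyl on the Fused Ring

The compounds below may be only part of what the source reports. "The series", "measured", "known", "first", "only" and "open" are said of these compounds alone.

Compound 3 `CC#C[C@@H](CC(=O)O)c1ccc(OC[C@H]2COc3ccc(C)cc3O2)cc1` gives 120 nM in a functional assay on HEK293 cells for agonist activity at Free fatty acid receptor 1 (Homo sapiens), read by fluorescence and calcium flux, with a stated time of 10 min (on this read-out lower numbers stand for an effect already at smaller amounts and higher numbers for an effect only at larger amounts of compound), the second highest of three numbers. Its nearest neighbour is compound 2 `CC#C[C@@H](CC(=O)O)c1ccc(OC[C@H]2COc3ccccc3O2)cc1`, which gives 90 nM; the step of a 1.3-fold higher number from compound 2 to compound 3 (0.12 log units; within the scatter) lies within the scatter. Furthest away stands compound 1 `Cn1ccnc1C(CC(=O)O)c1ccc(OCC2COc3ccc(Cl)cc3O2)cc1`, which gives 5880 nM. Compound 4 `CC#C[C@@H](CC(=O)O)c1ccc(OC[C@H]2COc3ccc(OC(F)(F)F)cc3O2)cc1` differs from compound 3 by trifluoromethoxy in place of methyl on an aromatic carbon. Going by the values given here, no measured step exchanges methyl for trifluoromethoxy; the only step at this place, a 1.3-fold higher number from compound 2 to compound 3 (0.12 log units; within the scatter), shows that hydrogen and methyl there gave numbers within the scatter. The expectation for compound 4 is therefore a step of about a 1.3-fold higher number from compound 3 to compound 4 (0.10 log units; within the scatter), not beyond the scatter. Compound 4 is estimated at 150 nM, with a range from 50 nM to 450 nM.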

Compound 4, half-maximal effective concentration: 700 nM
The estimate for compound 4 lay 4.7-fold (0.67 log units) below the measured number; the measured number lies above the stated range.
By their numbers in this assay, from the lowest: compounds 2 and 3 (each within the scatter of the next); then compound 4; then compound 1.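

The place on the fused ring is not indifferent to its substituent, although hydrogen and methyl there had given numbers within the scatter. Trifluoromethoxy gives a 5.8-fold higher number from compound 3 to compound 4 (0.77 log units; beyond the scatter) and, against the unsubstituted compound, a 7.8-fold higher number from compound 2 to compound 4 (0.89 log units; beyond the scatter), so this change lowers agonist potency at this place. Nothing available bears on why this happens. From the compounds shown here alone, it remains open whether this loss is peculiar to trifluoromethoxy or extends to other groups, such as methoxy, a nitrile or an amine, at this place. The compounds also leave open how trifluoromethoxy would behave on another carbon of this ring.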